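Carbamoyl for Fluorine on the Amide Nitrogen

A few compounds are considered here, and "the series" means these few. Any claim that something is new, unique, unknown or untested is made for them only; others in the source may bear on it.

Of the compounds shown here, three sharing one core have been tested in an ADME assay on LLC-MK2 cells (Macaca mulatta) for cytotoxicity, read by spectrophotometry and crystal violet staining, with a stated time of 4 days; on this read-out higher numbers stand for lower toxicity in this test and lower numbers for higher toxicity in this test. Compound 1 `CC(C)n1ncc2c(C(=O)Nc3ccc(F)c(S(N)(=O)=O)c3)cc(-c3cccs3)nc21` gives 50000 nM. For compound 3 `CC(C)n1ncc2c(C(=O)Nc3ccc(F)cc3)cc(-c3cccs3)nc21` the assay reports only a limit, > 200000 nM. For compound 2 `CC(C)n1ncc2c(C(=O)Nc3ccc(F)cc3)cc(-c3ccco3)nc21` the result is likewise only a limit, > 200000 nM. Compound 3 thus stands at the limit of > 200000 nM in this assay, at which 2 of the 3 values shown sit, the upper edge of what this assay can report. The step of an at least 4.0-fold higher number from compound 1 to compound 3 (0.60 log units; beyond the scatter) shows that hydrogen in place of sulfamoyl raised the number, whereas a step that the two limits leave unreadable from compound 2 to compound 3 cannot be read. Compound 4 `CC(C)n1ncc2c(C(=O)Nc3cccc(C(N)=O)c3)cc(-c3cccs3)nc21` differs from compound 3 by 3-carbamoylphenyl in place of 4-fluorophenyl on an amide-type nitrogen, bringing in a carbamoyl group where compound 1 carried a sulfamoyl group. By analogy with an at least 4.0-fold higher number from compound 1 to compound 3 (0.60 log units; beyond the scatter) a modestly lower number is expected for compound 4, estimated at 100000 nM, within 30000 nM to 200000 nM, a step of an at least 2.0-fold lower number from compound 3 to compound 4 (0.30 log units; that floor lies within the scatter).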

Compound 4, half-maximal cytotoxic concentration: 25000 nM
The estimate for compound 4 lay 4.0-fold (0.60 log units) above the measured number; measured number below the stated range.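

In this assay, 3-carbamoylphenyl in place of 4-fluorophenyl on the amide-type nitrogen gives an at least 8.0-fold lower number from compound 3 to compound 4 (0.90 log units; beyond the scatter), so this change raises toxicity in this test. Until now, only the loss of hydrogen to sulfamoyl had brought the number down; a change of the whole aromatic group on this nitrogen now does so too. The true step may be larger, because compound 3 carries only a limit: the limit of > 200000 nM in this assay, at which 2 of the 4 values shown sit.

On these data alone, this change removes the fluorine and adds the carbamoyl together, so the share of each stays open. As far as these compounds go, whether an amine or a carboxylic acid in place of the carbamoyl would also lower the number remains open too.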